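A few compounds are considered here, and "the series" means these few. Any claim that something is new, unique, unknown or untested is made for them only; others in the source may bear on it.

Compound 1 `COc1cc(-c2ccnc3cc(-c4ccc5cc[nH]c5c4)nn23)cc(OC)c1OC`: 125 nM
Compound 2 `COc1cc(-c2ccnc3c(-c4ccc(C)cc4)cnn23)cc(OC)c1OC`: > 10000 nM

In a functional assay on HeLa cells (Homo sapiens) for inhibition, read by CCK-8 assay, with a stated time of 48 h (on this read-out lower numbers stand for stronger inhibition and higher numbers for weaker inhibition), compound 1 gives 125 nM, the only number among the two results shown. For compound 2 the result is a limit of the assay, > 10000 nM, marked by the limit of > 10000 nM in this assay, at which 1 of the 2 values shown sits. Compound 3 `COc1cc(-c2ccnc3cc(-c4cccc(C#N)c4)nn23)cc(OC)c1OC` differs from compound 1 in one place (3-cyanophenyl in place of 1H-indol-6-yl on an aromatic carbon). For the measured compounds named here, no pair of measured compounds differs in a single place, so the size of this step in this assay has no measured counterpart; a weakening beyond the scatter is expected. Compound 3 is estimated at 500 nM, with a range from 150 nM to 3000 nM. The expected step of a 4.0-fold higher number from compound 1 to compound 3 (0.60 log units; beyond the scatter) is a weakening.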

Compound 3, half-maximal inhibitory concentration: > 10000 nM
Compound 3: a limit, no number; the forecaster's own chance of this, stated with the estimate: 15%; at least 20-fold (1.30 log units) between middle value and limit.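

For the compounds shown here, the first single-place step in this assay is large: replacing 1H-indol-6-yl with 3-cyanophenyl on this aromatic carbon gives an at least 80-fold higher number from compound 1 to compound 3 (1.90 log units; beyond the scatter) and removes the inhibition seen with compound 1 within the tested range. The position therefore does not accept every aromatic group, and 3-cyanophenyl is not a working replacement for 1H-indol-6-yl here. The step has no upper bound, since compound 3 gives a limit of the assay and not a number: the limit of > 10000 nM in this assay, at which 2 of the 3 values shown sit.

On these data alone, whether a plain phenyl or an aminophenyl group at this place would keep the inhibition stays open. So does whether the nitrile or the loss of the five-membered ring of the indole accounts for the step.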